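Propyl in place of 2-fluorophenyl at the ether carbon

This account rests on a few compounds, and the source may have more. Where it says the series, first, only, none or still open, it means among the compounds named here.

Compound 1 `CCc1nncn1-c1ccc(OCc2ccccc2F)cc1` and compound 2 `CCc1nncn1-c1ccc(OCc2cccc(Cl)c2)cc1` have been measured in a functional assay on the whole organism (strain C57B/6) with Mus musculus as the target, in the maximal electroshock model; a lower number here means that less compound is needed, a higher number that more compound is needed for the effect. Compound 1 gives 21.2 mg/kg, and compound 2 gives 27.4 mg/kg. Among the compounds with values here, compound 1 thus stands at the lowest of the two numbers, with compound 2 as its nearest neighbour, but the only measured step, a 1.3-fold higher number from compound 1 to compound 2 (0.11 log units; within the scatter), lies within the scatter, so the two compounds cannot be ordered.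

Compound 3 `CCCCOc1ccc(-n2cnnc2CC)cc1` remains to be measured. Its difference from compound 1: propyl in place of 2-fluorophenyl on a saturated chain carbon bound to an oxygen on an aromatic ring. Within the data shown here, the single measured step, from compound 1 to compound 2, exchanges one aromatic group for another at the same place and stays within the scatter; no measured step exchanges an aromatic group for a chain, so nothing known bears directly on the change in compound 3. The only support is that this place accepted one exchange without a shift beyond the scatter. Compound 3 is therefore expected to show a step of a 1.4-fold higher number from compound 1 to compound 3 (0.15 log units; within the scatter), small, with a wide range open toward a higher number. For compound 3 the estimate in this assay is 30 mg/kg, between 12 mg/kg and 75 mg/kg.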

Compound 3, dose for half-maximal effect: > 100 mg/kg
Compound 3: a limit, no number (the forecaster's own chance of this, stated with the estimate: 10%); middle value at least 3.3-fold (0.52 log units) away from the limit.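

In this assay compound 3 gives > 100 mg/kg, which is a limit of the assay and not a number. The change from an aromatic group to propyl gives an at least 4.7-fold higher number from compound 1 to compound 3 (0.67 log units; beyond the scatter) and an at least 3.6-fold higher number from compound 2 to compound 3 (0.56 log units; beyond the scatter), whereas the exchange of one aromatic group for the other gives a 1.3-fold higher number from compound 1 to compound 2 (0.11 log units; within the scatter). This place on a saturated chain carbon bound to an oxygen on an aromatic ring therefore accepts 3-chlorophenyl in place of 2-fluorophenyl but not propyl, so among these compounds only the two with an aromatic ring at this place reach a number in the maximal electroshock read-out, while the one with the chain stays at the limit.

As far as these compounds go, the steps to compound 3 give only a lower bound, so the true size of the change stays open, and a single chain does not show whether the ring itself or the size of the group counts. A cyclohexyl ring at this place would separate those two readings, and a longer chain or a pyridyl ring would show how far the tolerated range reaches.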